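The source may hold more compounds than are shown below. What is called first, only, known or untested is meant among the compounds shown, and "the series" means these compounds.

Three compounds have been measured in a functional assay on HEp-2 cells (Homo sapiens) for inhibition; a lower number here means a stronger inhibitor, a higher number a weaker inhibitor:

compound 1, `CC(=O)OC(C)n1cnc2c(Cl)nc(I)nc21`, 6310 nM
compound 2, `CC(O)n1cnc2c(Cl)nc(I)nc21`, > 500000 nM
compound 3, `CC(=O)OC(C)n1cnc2c(S)nc(F)nc21`, 200000 nM

Compound 1 gives the lowest number of the three in this assay. For compound 2 the value is not a number but a limit of the assay, (the limit of > 500000 nM in this assay, at which 1 of the 3 values shown sits). The change from compound 1 to compound 2 is hydrogen in place of acetyl on an oxygen on a saturated carbon and it made a step of an at least 79-fold higher number from compound 1 to compound 2 (1.89 log units; beyond the scatter). Compound 3 stands far from compound 1; how the two cores differ is not broken down here. In this assay compound 3 gives 200000 nM, a high number already.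

Compound 4, `CC(O)n1cnc2c(S)nc(F)nc21`, has not yet been measured. It differs from compound 3 by hydrogen in place of acetyl on an oxygen on a saturated carbon, the same change that was made from compound 1 to compound 2, at the same kind of place. Compound 4 is expected to give a much higher number than compound 3, with an estimated step of a 15-fold higher number from compound 3 to compound 4 (1.18 log units; beyond the scatter), because the same change gave an at least 79-fold higher number from compound 1 to compound 2 (1.89 log units; beyond the scatter) and compound 2 sits at the limit of > 500000 nM in this assay, at which 1 of the 3 values shown sits. Since compound 3 starts out far weaker than compound 1, the expected value for compound 4 is 3000000 nM, somewhere between 400000 nM and 30000000 nM, and it is considered likely that this assay will again report only a limit rather than a number for compound 4.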

Compound 4, half-maximal inhibitory concentration: > 500000 nM
Compound 4 ended at the assay's limit; the forecaster's own chance of this, stated with the estimate: 85%; the middle value lies beyond the limit too.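

In this assay, the change from acetoxy to hydroxy on the core of compound 3 again went toward a weaker number, with an at least 2.5-fold higher number from compound 3 to compound 4 (0.39 log units; beyond the scatter). Set side by side, the two cores give this picture: the same change on two cores in this assay, an at least 79-fold higher number (1.89 log units; beyond the scatter) from compound 1 to compound 2 and an at least 2.5-fold higher number (0.39 log units; beyond the scatter) from compound 3 to compound 4; the limit leaves it open whether they differ. The direction of the change therefore held on both cores shown, but that rests on a single pair per core, and the size of the step on each core stays unknown, since compound 2 and compound 4 both end at a limit and not at a number: the limit of > 500000 nM in this assay, at which 2 of the 4 values shown sit.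

The compounds shown leave open whether the acetyl group itself matters or whether another ester on that oxygen, such as a longer chain like butanoyl, or a methyl ether, would also keep a measurable number. They also leave open how the chloro and iodo groups of compound 1 and the thiol and fluoro groups of compound 3 each contribute, as these groups change together, and whether an amine in place of the thiol would bring the acetoxy compound closer to compound 1.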